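Half-life expected to hold after a pyridinyl group exchange

The source may hold more compounds than are shown below. What is called first, only, known or untested is meant among the compounds shown, and "the series" means these compounds.

In an ADME assay on microsomes from liver (Homo sapiens) for metabolic stability (a lower number here means that the compound disappears faster, a higher number that the compound lasts longer), compound 1 `COc1nc2ccc(Br)cc2cc1[C@@H](c1cccnc1N(C)C)[C@@](O)(CCN(C)C)c1cccc(F)c1` gives 0.25 h and compound 2 `COc1cc([C@H](c2cc3cc(Br)ccc3nc2OC)[C@@](O)(CCN(C)C)c2cccc(F)c2)cnc1OC` gives 0.317 h, two values within the scatter of each other. Compound 3 `CCSc1ccc([C@H](c2cc3cc(Br)ccc3nc2OC)[C@@](O)(CCN(C)C)c2cccc(F)c2)cn1` carries 6-(ethylsulfanyl)pyridin-3-yl in place of 5,6-dimethoxypyridin-3-yl on a saturated chain carbon bound to an aromatic carbon and a saturated chain carbon. Within the data shown here, only one measured step bears on this change, at the same place, and a 1.3-fold higher number from compound 1 to compound 2 (0.10 log units; within the scatter). A single small step is thin evidence, yet it gives no reason to expect a shift beyond the scatter in this assay. The expected step is a 1.3-fold lower number from compound 2 to compound 3 (0.10 log units; within the scatter). For compound 3 the estimated half-life is 0.25 h, with an expected range of 0.12 h to 0.55 h.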

Compound 3, half-life: 1.07 h
For compound 3 the middle estimate is 4.3-fold (0.63 log units) below the measured one, outside the stated range (above it).
By their numbers in this assay, from the lowest: compounds 1 and 2 (each within the scatter of the next); then compound 3.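

At the place on a saturated chain carbon bound to an aromatic carbon and a saturated chain carbon, the choice of pyridinyl group can move the reading in this assay beyond the scatter, which the exchange between compounds 1 and 2 did not show. Placing 6-(ethylsulfanyl)pyridin-3-yl there gives a 3.4-fold higher number from compound 2 to compound 3 (0.53 log units; beyond the scatter) and a 4.3-fold higher number from compound 1 to compound 3 (0.63 log units; beyond the scatter) in turn. Nothing available explains this gain.

The compounds shown do not separate the sulfur from the ethyl chain. Going by these compounds, whether 6-ethoxypyridin-3-yl or 6-(methylsulfanyl)pyridin-3-yl would keep the gain remains open.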